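The compounds below may be only part of what the source reports. "The series", "measured", "known", "first", "only" and "open" are said of these compounds alone.

Measured so far in an assay on isolated protein for inhibition of Retinaldehyde dehydrogenase 3 (Homo sapiens); on this read-out lower numbers stand for stronger inhibition and higher numbers for weaker inhibition:
- compound 1 `COc1cccc(C(C)Sc2nc3c(cnn3C)c(=O)n2-c2ccccc2)c1` gives 174 nM
- compound 2 `CC(Sc1nc2c(cnn2C)c(=O)n1-c1ccc(CCO)cc1)c1ccccc1` gives 3000 nM

Compound 1 has the lowest of the two numbers in this assay. Going by the values given here, compound 2 gives a clearly higher number, a gap that lies beyond the scatter of repeated measurements; the two differ in more than one place, so the pair shows only that the two values lie far apart, and nothing more can be read from it.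

Compound 3 `CC(Sc1nc2c(cnn2C)c(=O)n1-c1ccccc1)c1cccc(O)c1` is not yet measured. Its difference from compound 1 is hydrogen in place of methyl on an oxygen on an aromatic ring. Among the compounds with values here, no measured pair in this set shows what such a change does, so the expectation rests on the value of compound 1 alone. Because compound 1 gives 174 nM, compound 3 is expected to land near that number, with the step of a 1.4-fold higher number from compound 1 to compound 3 (0.16 log units; within the scatter) estimated to stay within the scatter, in no firm direction. The estimate for compound 3 is 250 nM, with a range from 80 nM to 800 nM.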

Compound 3, half-maximal inhibitory concentration: 91 nM
The estimate for compound 3 lay 2.7-fold (0.44 log units) above the measured number; the measured number falls inside the stated range.
By their numbers in this assay, from the lowest: compounds 3 and 1 (each within the scatter of the next); then compound 2.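

In this assay, going by these compounds alone, the pair gives the first comparison that differs in one place: the step is a 1.9-fold lower number from compound 1 to compound 3 (0.28 log units; within the scatter) for hydrogen in place of methyl on an oxygen on an aromatic ring. On this read-out, therefore, 3-methoxyphenyl and 3-hydroxyphenyl cannot be told apart, and the methyl on that oxygen is not required for a value in the range that compound 1 shows, at least with the rest of the structure held as it is in compound 1 and compound 3. No measurement at hand says why the two compounds read alike.

What the compounds shown leave open is whether this tolerance reaches beyond hydrogen and methyl on that oxygen, for instance to a longer chain such as ethyl or propyl, or whether an amine or a carboxylic acid could stand in place of the hydroxy group at the same place. Within the data shown here, compound 2 still differs from both compound 1 and compound 3 in more than one place, so the single change that separates its much higher number from theirs also remains unresolved.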